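A few compounds are considered here, and "the series" means these few. Any claim that something is new, unique, unknown or untested is made for them only; others in the source may bear on it.

Within the data shown here, compound 3 `COc1cccc2c1c(C(=O)/C=C(\O)C(=O)O)cn2Cc1cccc(F)c1` gives 65800 nM in an ADME assay on MT4 cells (Homo sapiens) for cytotoxicity, read by MTT assay (on this read-out lower numbers stand for higher toxicity in this test and higher numbers for lower toxicity in this test), the second highest of the three numbers so far. Compound 1 `COc1cccc2c1c(C(=O)/C=C(\O)C(=O)O)cn2Cc1ccc(F)c(F)c1` gives 71000 nM, and the two lie within the usual scatter of each other (a 1.1-fold lower number from compound 1 to compound 3 (0.03 log units; within the scatter)), while compound 2 `COc1cccc2c1c(C(=O)/C=C(\O)C(=O)O)cn2Cc1ccc(F)cc1F` gives 20800 nM. Compound 4 `COc1cccc2c1c(C(=O)/C=C(\O)C(=O)O)cn2Cc1c(F)cccc1F` differs from compound 3 by 2,6-difluorophenyl in place of 3-fluorophenyl on a saturated chain carbon bound to an aromatic nitrogen. Two earlier steps change the same benzyl group: a 3.4-fold lower number from compound 1 to compound 2 (0.53 log units; beyond the scatter) and a 3.2-fold higher number from compound 2 to compound 3 (0.50 log units; beyond the scatter); the 2,4-difluorophenyl pattern went with a lower number, whereas 3,4-difluorophenyl did not, so the effect of a second fluorine depends on where it sits. Among the measured compounds shown here, a modest lowering is therefore expected for compound 4, a 1.6-fold lower number from compound 3 to compound 4 (0.22 log units; within the scatter), because a 3.4-fold lower number from compound 1 to compound 2 (0.53 log units; beyond the scatter) is the closest precedent for two fluorines. Compound 4 is estimated at 40000 nM, between 15000 nM and 100000 nM.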

Compound 4, half-maximal cytotoxic concentration: 44300 nM
For compound 4 the middle estimate is 1.1-fold (0.04 log units) below the measured one; the measured number falls inside the stated range.
By their numbers in this assay, from the lowest: compound 2; then compounds 4, 3 and 1 (each within the scatter of the next).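

In this assay the 2,6-difluorobenzyl group stays within the scatter of the 3-fluorobenzyl group (a 1.5-fold lower number from compound 3 to compound 4 (0.17 log units; within the scatter)) and of the 3,4-difluorobenzyl group (a 1.6-fold lower number from compound 1 to compound 4 (0.20 log units; within the scatter)), yet stands apart from the 2,4-difluorobenzyl group (a 2.1-fold higher number from compound 2 to compound 4 (0.33 log units; beyond the scatter)). A second fluorine on this ring therefore does not by itself go with a lower number: compound 2 stands apart, while compound 1 and compound 4 go against such a pattern. Nothing measured here explains this difference. The compounds shown leave open how a benzyl ring carrying chlorine or an amine, or a plain benzyl without fluorine, would read in this assay here.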